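The source may report more compounds than this note shows. Statements on the series, on what has been measured and on what is new or still open speak of the compounds shown alone.

The three measured compounds are:
compound 1, `Cc1cc(NC(=O)Nc2ccc(C(C)(C)C)cc2)c2ccccc2n1`, 142 10^-6 cm/s;
compound 2, `CSc1ccc(NC(=O)Nc2cc(C)nc3ccccc23)cc1`, 473 10^-6 cm/s;
compound 3, `Cc1cc(NC(=O)Nc2ccccc2C(C)(C)C)c2ccccc2n1`, 27 10^-6 cm/s.

All three were measured in an ADME assay for permeability, using PAMPA, at pH 7.4; on this read-out higher numbers stand for higher permeability and lower numbers for lower permeability. Compound 1 and compound 2 share a core and differ in one place: methylsulfanyl in place of tert-butyl on an aromatic carbon. That change gave a 3.3-fold higher number from compound 1 to compound 2 (0.52 log units; beyond the scatter). Compound 3 has the same atoms as compound 1, joined differently; the difference between the two cores is not broken down here. Among the three, compound 3 gives the lowest number, and its steps to both other compounds lie beyond the scatter.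

Compound 4, `CSc1ccccc1NC(=O)Nc1cc(C)nc2ccccc12`, has not yet been measured in this assay. It differs from compound 3 in one place: methylsulfanyl in place of tert-butyl on an aromatic carbon. Within the data shown here, this is the same kind of change as the one from compound 1 to compound 2, but not the same: in the earlier pair the place is para to a large group, whereas in compound 3 and compound 4 it is ortho to a large group. Only that one earlier occurrence is available as a guide.

On that basis an upward step of similar size is expected from compound 3 to compound 4, a 3.0-fold higher number from compound 3 to compound 4 (0.47 log units; beyond the scatter). The expectation rests on the earlier step, a 3.3-fold higher number from compound 1 to compound 2 (0.52 log units; beyond the scatter), while the changed place widens the uncertainty. In this assay compound 4 is therefore estimated at 80 10^-6 cm/s, within a range from 35 10^-6 cm/s to 180 10^-6 cm/s.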

Compound 4, apparent permeability: 1260 10^-6 cm/s
Estimate against measurement, compound 4: 16-fold (1.20 log units) below; the measured number lies above the stated range.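

In this assay, methylsulfanyl in place of tert-butyl on an aromatic carbon gave a 47-fold higher number from compound 3 to compound 4 (1.67 log units; beyond the scatter) and so raised the number on this core as well, but the size of the step did not carry over from the earlier pair: the same change on two cores in this assay, a 3.3-fold higher number (0.52 log units; beyond the scatter) from compound 1 to compound 2 and a 47-fold higher number (1.67 log units; beyond the scatter) from compound 3 to compound 4, 14-fold (1.15 log units) apart, beyond the scatter of two such steps. Within these two pairs the direction of the change held while its size did not, so a step seen on one core gave the direction on the other but was a poor guide to how large the step would be. The two pairs do not show why the steps differ, and they cannot tell whether the place of the change, ortho to a large group in compound 3 and compound 4 but not in the earlier pair, accounts for the gap, nor do they establish a rule for the wider series.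

The compounds shown leave open how a methoxy group, a longer thioether chain or an amine would behave at this same place on either core. They also leave open whether the upward direction of this change would persist on any core other than these two.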